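Swapping the Aryl Group on the Shared Core

The compounds below may be only part of what the source reports. "The series", "measured", "known", "first", "only" and "open" are said of these compounds alone.

Within the data shown here, in a functional assay on BJAB cells (Homo sapiens) for antiproliferative activity, with a stated time of 4 days (a lower number here means that less compound is needed, a higher number that more compound is needed for the effect), compound 1 `Cc1ccccc1-c1c(C)nn(-c2nc(-c3ccc(Cl)c(Cl)c3)c(SC(C)C)s2)c1C(=O)O` gives 5500 nM and stands beside the only other measured compound, compound 2 `Cc1nn(-c2nc(-c3ccc(Cl)c(Cl)c3)c(SC(C)C)s2)c(C(=O)O)c1-c1cnn(C)c1`, which gives 6800 nM; the step of a 1.2-fold higher number from compound 1 to compound 2 (0.09 log units; within the scatter) replaces the same aromatic carbon substituent. Compound 3 `COc1cccc(-c2c(C)nn(-c3nc(-c4ccc(Cl)c(Cl)c4)c(SC(C)C)s3)c2C(=O)O)c1` differs from compound 1 by 3-methoxyphenyl in place of 2-methylphenyl on an aromatic carbon. Among the measured compounds shown here, the single step that bears on this change is that from compound 1 to compound 2, and it stayed within the scatter, so no shift beyond the scatter is expected in this assay . Compound 3 is therefore estimated at 5500 nM, between 2500 nM and 12000 nM, an expected no change at the digits printed from compound 1 to compound 3 (within the scatter).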

Compound 3, half-maximal effective concentration: 14000 nM
Compound 3: middle estimate off by 2.5-fold (0.41 log units), on the low side; measured number above the stated range.
By their numbers in this assay, from the lowest: compounds 1 and 2 (each within the scatter of the next); then compound 3.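

In this assay, 3-methoxyphenyl on this aromatic carbon brings a 2.5-fold higher number from compound 1 to compound 3 (0.41 log units; beyond the scatter) and also a 2.1-fold higher number from compound 2 to compound 3 (0.31 log units; beyond the scatter), whereas 2-methylphenyl and 1-methyl-1H-pyrazol-4-yl had stayed within the scatter of each other. This position therefore does respond to the choice of aryl group, though only modestly so far, which the earlier pair did not show. Nothing at hand accounts for this rise. As far as these compounds go, what remains open is whether the rise follows the methoxy group itself, and where an unsubstituted phenyl or a 3-aminophenyl would fall in this place.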